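The source may hold more compounds than are shown below. What is called first, only, known or untested is meant among the compounds shown, and "the series" means these compounds.

Compound 1 `COc1ccc(OC)c(-c2cc(-c3ccc(C(=O)N4CCCC4)s3)on2)c1`: in a functional assay on PC-3 cells (Homo sapiens) for cytotoxicity, read by XTT assay, with a stated time of 72 h (a lower number here means a stronger inhibitor, a higher number a weaker inhibitor), compound 1 gives > 30000 nM, which is a limit of the assay and not a number.
Compound 2 `COc1ccc(OC)c(-c2cc(-c3ccc(C(=O)N(C)C)s3)on2)c1`: compound 2 gives > 30000 nM, likewise a limit.
Compound 3 `COc1ccc(OC)c(-c2cc(-c3ccc(C(=O)N4CCCCC4)s3)on2)c1`: compound 3 gives > 30000 nM, also a limit.

Compound 3 therefore stands at the limit of > 30000 nM in this assay, at which 3 of the 3 values shown sit, with no reading of its own. The change to compound 4 `COc1ccc(OC)c(-c2cc(-c3ccc(C(=O)NC4CC4)s3)on2)c1` is this: cyclopropylamino in place of piperidin-1-yl on a carbonyl carbon. The measured steps that bear on it, a step that the two limits leave unreadable from compound 1 to compound 2, a step that the two limits leave unreadable from compound 1 to compound 3 and a step that the two limits leave unreadable from compound 2 to compound 3, are all unreadable because both ends of each sit at the limit of > 30000 nM in this assay, at which 3 of the 3 values shown sit. Exchanges of the substituent on the amide nitrogen across compound 1, compound 2 and compound 3 thus gave no readable movement, so no step beyond the scatter is expected here, and compound 4 is expected most likely to return a limit as well. The estimate for compound 4 is 30000 nM, range 10000 nM to 100000 nM, an expected step of a number no higher from compound 3 to compound 4 (the limit leaves the size open).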

Compound 4, half-maximal inhibitory concentration: 7800 nM
Compound 4: middle estimate off by 3.8-fold (0.59 log units), on the high side, outside the stated range (below it).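

In this assay the group on the carbonyl carbon can move the read-out after all: cyclopropylamino gives a readable change against all three earlier amides (an at least 3.8-fold lower number from compound 3 to compound 4 (0.58 log units; beyond the scatter)) (an at least 3.8-fold lower number from compound 2 to compound 4 (0.58 log units; beyond the scatter)) (an at least 3.8-fold lower number from compound 1 to compound 4 (0.58 log units; beyond the scatter)). Compound 4 alone among these compounds carries the amide hydrogen, but the same change also brings in the three-membered ring. The steps among compound 1, compound 2 and compound 3 cannot be read: the limit of > 30000 nM in this assay, at which 3 of the 4 values shown sit.

The compounds shown do not separate the amide hydrogen from the cyclopropyl ring. A methylamino or cyclobutylamino group in the same place would bear on that.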